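Lengthening the amine-bearing chain on the shared core

A few compounds are considered here, and "the series" means these few. Any claim that something is new, unique, unknown or untested is made for them only; others in the source may bear on it.

Measured so far:
Compound 1, `CC(=O)NCCN(C)c1cccc(OCCCCN)c1`, 0.35
Compound 2, `CC(=O)NCCN(C)c1cccc(OCCCCCCNC(=O)Oc2cccc(-c3cccc(O)c3)c2)c1`, 0.94
Compound 3, `CCC(=O)NCCN(C)c1cccc(OCCCCCCNC(=O)Oc2cccc(-c3ccccc3)c2)c1`, 0.88

In a functional assay on cells for agonist activity at melatonin receptor type 1B (Homo sapiens), read by GTPgammaS binding, with a stated time of 30 min (a higher number here means a larger maximal response, a lower number a smaller maximal response), compound 1 gives the lowest of the three numbers; compound 3 lies higher by an amount beyond the scatter, and compound 2 lies higher still, also beyond the scatter. Compounds 2 and 3 carry the longer chain together with a carbamate, so they tell only that the longer chain is compatible with a large response. Compound 4, `CC(=O)NCCN(C)c1cccc(OCCCCCCN)c1`, differs from compound 1 in one place: 2-aminoethyl in place of amino on a saturated chain carbon, four bonds along the chain from an oxygen on an aromatic ring. Among the measured compounds shown here, with no measured step of this kind, the expectation is a modest upward step, near the edge of the scatter, a number 0.15 higher from compound 1 to compound 4 (beyond the scatter). Compound 4 is therefore estimated at 0.5, within 0.3 to 0.8.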

Compound 4, intrinsic activity: the largest response reached, as a fraction of the reference agonist's: 0.08
Beside the measured number, compound 4's estimate is 0.42 above it; the measured number lies below the stated range.
By their numbers in this assay, from the lowest: compound 4; then compound 1; then compounds 3 and 2 (each within the scatter of the next).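

In this assay, placing 2-aminoethyl in place of amino on this saturated chain carbon gives a number 0.27 lower from compound 1 to compound 4 (beyond the scatter). Among the compounds shown here, with the amine still free at the chain end, lengthening the chain alone therefore lowers the maximal response, which the earlier compounds, differing from compound 1 in more than one place, could not show. Nothing available gives a reason for this fall.

Still open, on these data alone, is whether the response falls further with 3-aminopropyl in place of 2-aminoethyl. Also open, as far as these compounds go, is how a carboxylic acid or an alcohol at the chain end would compare with the amine.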